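This account rests on a few compounds, and the source may have more. Where it says the series, first, only, none or still open, it means among the compounds named here.

Working notes on the series. Compound 1 `c1ccc(Sc2ncnc3[nH]cnc23)cc1` and compound 2 `Fc1ccc(Sc2ncnc3[nH]cnc23)cc1` share one core; compound 3 `Cn1cnc2c(SCc3ccccc3)ncnc21` is built on another, and the difference between the two cores is not broken down here. In an assay on isolated protein for inhibition of RAC-alpha serine/threonine-protein kinase (Homo sapiens), tested at 30 uM (on this read-out higher numbers stand for more inhibition at the one concentration tested (going by the name of the read-out) and lower numbers for less inhibition), compound 1 gives 0%, compound 2 gives 0% and compound 3 gives 4%; all three values lie within the scatter of one another, so no order among them is claimed.

Within the data shown here, the only change that has been measured is fluoro in place of hydrogen on an aromatic carbon, which gave no change at the digits printed from compound 1 to compound 2 (within the scatter). Compound 4 `Cn1cnc2c(SCc3ccc(F)cc3)ncnc21` is compound 3 carrying the same change, (fluoro in place of hydrogen on an aromatic carbon), set at the same kind of place as in the earlier pair: on an aromatic carbon of a six-membered aromatic ring of carbon only, para to a large group. Among the compounds shown this change occurs twice.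

The expectation for compound 4 rests on the step from compound 1 to compound 2 no change at the digits printed from compound 1 to compound 2 (within the scatter) and on compound 3 at 4%; the step from compound 3 to compound 4 is expected to be no change at the digits printed from compound 3 to compound 4 (within the scatter). Compound 4 is thus estimated at 4%, expected to fall between -5% and 14%.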

Compound 4, a percentage reported as inhibition, at one concentration (the size of the read-out at that concentration, not a potency): 11%
For compound 4 the middle estimate is 7 percentage points below the measured one, and the stated range covers the measured number.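

In this assay the same fluoro change now gives a number 7 percentage points higher from compound 3 to compound 4 (within the scatter), and set beside the earlier step on the other core it does not separate from it: the same change on two cores in this assay, no change at the digits printed (within the scatter) from compound 1 to compound 2 and a number 7 percentage points higher (within the scatter) from compound 3 to compound 4, 7 percentage points apart, within the scatter of two such steps.

On these two pairs, then, the change carries from one core to the other with no difference that can be told from the scatter, on an aromatic carbon para to a large group in both cases. Among these compounds, this does not show that the two cores respond alike in general: there are only two pairs, each read at a single concentration, and such a read-out gives no potency.

The compounds shown leave open whether a group other than fluoro at that place, such as an amine, a carboxylic acid or a methoxy group, would give a step beyond the scatter on either core. They also leave open what a longer chain on the sulfur would do, and how much of any difference between compound 1 and compound 3 belongs to the core itself.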